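Replacing the tert-butoxy Group on the Carbonyl: Expected Tolerance

This account rests on a few compounds, and the source may have more. Where it says the series, first, only, none or still open, it means among the compounds named here.

Compound 1 `Cc1cn([C@@H]2O[C@H](CO[Si](C)(C)C(C)(C)C)[C@@]3(OS(=O)(=O)C=C3N)[C@H]2O[Si](C)(C)C(C)(C)C)c(=O)n(C(=O)OC(C)(C)C)c1=O`: 26000 nM
Compound 2 `Cc1cn([C@@H]2O[C@H](CO[Si](C)(C)C(C)(C)C)[C@@]3(OS(=O)(=O)C=C3N)[C@H]2O[Si](C)(C)C(C)(C)C)c(=O)n(C(=O)CCCBr)c1=O`: 11000 nM
Compound 3 `Cc1cn([C@@H]2O[C@H](CO[Si](C)(C)C(C)(C)C)[C@@]3(OS(=O)(=O)C=C3N)[C@H]2O[Si](C)(C)C(C)(C)C)c(=O)n(C(=O)C2CC2)c1=O`: 11000 nM

In an ADME assay on CCRF-CEM cells (Homo sapiens) for cytotoxicity, with a stated time of 4 days (a lower number here means that less compound is tolerated, a higher number that more compound is tolerated), compound 1 gives the highest of the three numbers, so it is the compound of which the cells tolerate most. Compound 2 and compound 3 both sit lower: a 2.4-fold lower number from compound 1 to compound 2 (0.37 log units; beyond the scatter) and a 2.4-fold lower number from compound 1 to compound 3 (0.37 log units; beyond the scatter), while between the two of them no change at the digits printed from compound 2 to compound 3 (within the scatter). Compound 4 `Cc1cn([C@@H]2O[C@H](CO[Si](C)(C)C(C)(C)C)[C@@]3(OS(=O)(=O)C=C3N)[C@H]2O[Si](C)(C)C(C)(C)C)c(=O)n(C(=O)CCCC(=O)OC(C)(C)C)c1=O` has not yet been measured. It differs from compound 1 at one spot: 3-(tert-butoxycarbonyl)propyl in place of tert-butoxy on a carbonyl carbon. Both measured steps away from compound 1 replaced the same tert-butoxy group on that carbonyl carbon, each with a modest drop in the number, and the two replacements did not differ from each other. The change to compound 4 removes tert-butoxy from the same carbonyl carbon, so a modest drop of similar size is expected, a 2.2-fold lower number from compound 1 to compound 4 (0.34 log units; beyond the scatter). Compound 4 is therefore estimated at 12000 nM, with a range from 6000 nM to 25000 nM.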

Compound 4, half-maximal cytotoxic concentration: 11000 nM
For compound 4 the middle estimate is 1.1-fold (0.04 log units) above the measured one, within the range that was stated.
By their numbers in this assay, from the lowest: compounds 2, 3 and 4 (each within the scatter of the next); then compound 1.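

In this assay, the replacement of tert-butoxy gives a 2.4-fold lower number from compound 1 to compound 4 (0.37 log units; beyond the scatter), even though the entering 3-(tert-butoxycarbonyl)propyl is the largest group here and brings a second carbonyl. The other two replacements offer no separation from it, with no change at the digits printed from compound 3 to compound 4 (within the scatter) and no change at the digits printed from compound 2 to compound 4 (within the scatter), so a cyclopropyl group, a bromo-ended chain and a tert-butoxycarbonyl-ended chain all read alike at this carbonyl carbon, and among these four compounds only compound 1, with tert-butoxy, stands apart. Nothing available explains the drop or this flatness.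

As far as these compounds go, it remains open whether a carboxylic acid or an amine at the end of the chain, or a longer chain, would stay at this level. From the compounds shown here alone, it is also open whether a methoxy group on the same carbonyl carbon would match tert-butoxy or the other three groups.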